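The compounds below may be only part of what the source reports. "The series", "measured", "known", "first", "only" and "open" are said of these compounds alone.

Measured so far:
- compound 1 `CC[S+]([O-])CCCCN=C=S` gives 3850 nM in a functional assay on HCT-116 cells (Homo sapiens) for cytotoxicity, read by MTT assay, with a stated time of 72 h; on this read-out lower numbers stand for stronger inhibition and higher numbers for weaker inhibition
- compound 2 `CCC[S+]([O-])CCCCN=C=S` gives 3950 nM in this assay
- compound 3 `CCCC[S+]([O-])CCCCN=C=S` is not yet measured

Among the compounds with values here, compound 2 at 3950 nM stands level with compound 1 within the scatter, and these are the only two numbers so far. Going on to compound 3, the change is methyl in place of hydrogen on a saturated chain carbon, three bonds along the chain from a sulfur (propyl to butyl). Within the data shown here, one measured step bears on it, namely a 1.0-fold higher number from compound 1 to compound 2 (0.01 log units; within the scatter) for methyl in place of hydrogen on a saturated chain carbon, two bonds along the chain from a sulfur. That single step is small, so no move beyond the scatter is expected in this assay and neither direction is favoured. The expected step is a 1.0-fold lower number from compound 2 to compound 3 (0.01 log units; within the scatter) as an estimate resting on that one comparison. For compound 3 the estimate is 3900 nM with an expected range from 2200 nM to 6500 nM for now.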

Compound 3, half-maximal inhibitory concentration: 2810 nM
Compound 3: the middle estimate sits 1.4-fold (0.14 log units) above what was measured, within the range that was stated.
By their numbers in this assay, from the lowest: compounds 3, 1 and 2 (each within the scatter of the next).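

In this assay, methyl in place of hydrogen three bonds along the chain from the sulfur (propyl to butyl) gives a 1.4-fold lower number from compound 2 to compound 3 (0.15 log units; within the scatter), and taking the ethyl group in place of hydrogen two bonds along the chain gives a 1.4-fold lower number from compound 1 to compound 3 (0.14 log units; within the scatter). The earlier pair tested a single addition, whereas these steps show that the same holds further out and over a two-carbon extension: the chain on the sulfur runs from ethyl to butyl without a move beyond the scatter. No measurement available here accounts for these numbers, and none bears on why the chain length makes so little difference.

From the compounds shown here alone, it remains open whether a longer chain such as hexyl or octyl would leave the number within the scatter. Equally open, going by these compounds, is how a phenyl ring or a benzyl group on the sulfur would read in this assay.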